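From butyl to tert-butyl: an estimate for compound 3

The source may hold more compounds than are shown below. What is called first, only, known or untested is meant among the compounds shown, and "the series" means these compounds.

Of the compounds shown here, two have numbers so far in a functional assay on OVCAR-3 cells (Homo sapiens) for inhibition (on this read-out lower numbers stand for stronger inhibition and higher numbers for weaker inhibition), and they stand apart. Compound 2 (`CCCCNC(=O)N1CC1C#N`) gives 12000 nM as the higher of the two numbers, which makes it the weaker inhibitor, and compound 1 (`N#CC1CN1C(=O)Nc1ccc(Cl)c(Cl)c1`) gives 5600 nM as the lower one, a gap beyond the usual scatter. Compound 3 (`CC(C)(C)NC(=O)N1CC1C#N`) has not been measured yet. It keeps the core of compound 2 but carries tert-butyl in place of butyl on an amide-type nitrogen. The two groups hold the same atoms, joined differently. Among the measured compounds shown here, no two measured compounds differ in only one place, so no measured step shows what such a swap does, and the expectation stays loose. The estimated step is a 1.2-fold higher number from compound 2 to compound 3 (0.07 log units; within the scatter) and nothing beyond the scatter is expected. For compound 3 the expected value is 14000 nM (estimated range 5000 nM to 40000 nM).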

Compound 3, half-maximal inhibitory concentration: 186000 nM
Estimate against measurement, compound 3: 13-fold (1.12 log units) below; the whole stated range lies below it.
By their numbers in this assay, from the lowest: compound 1; then compound 2; then compound 3.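

In this assay, swapping butyl for tert-butyl on this amide-type nitrogen gives a 16-fold higher number from compound 2 to compound 3 (1.19 log units; beyond the scatter), even though the two groups hold the same atoms, joined differently. Among the compounds shown here, this is the first measured step at this position, and it shows that the position does not treat all groups of the same size alike: how the carbons are joined is enough to weaken inhibition clearly. Nothing measured here says why the number rises.

The compounds shown leave open where other groups on this nitrogen would fall, such as ethyl, isobutyl, cyclohexyl or a longer chain like hexyl, and so whether the rise follows branching in general or belongs to tert-butyl alone. They also leave open whether the same swap would have a similar effect on a different core.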